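This account rests on a few compounds, and the source may have more. Where it says the series, first, only, none or still open, it means among the compounds named here.

In a functional assay on Huh-7 cells (Homo sapiens) for cytotoxicity, read by MTT assay, with a stated time of 3 days (a higher number here means that more compound is tolerated, a lower number that less compound is tolerated), compound 2 `OC[C@H]1O[C@@H](n2cnc3c(COc4ccccn4)ncnc32)[C@H](O)[C@@H]1O` gives > 250000 nM, which is a limit and not a number. Compound 1 `OC[C@H]1O[C@@H](n2cnc3c(Cn4ccc5ccccc54)ncnc32)[C@H](O)[C@@H]1O` gives > 250000 nM, also a limit. Compound 3 `CC(=O)N(Cc1ccccc1)Cc1ncnc2c1ncn2[C@@H]1O[C@H](CO)[C@@H](O)[C@H]1O` gives > 100000 nM, again a limit. Going by the values given here, every value so far is therefore a limit, as the limit of > 250000 nM in this assay, at which 2 of the 3 values shown sit, and the limit of > 100000 nM in this assay, at which 1 of the 3 values shown sits, show. Compound 4 `CC(C)N(Cc1ncnc2c1ncn2[C@@H]1O[C@H](CO)[C@@H](O)[C@H]1O)C(C)C` has diisopropylamino in place of (pyridin-2-yl)oxy on a saturated chain carbon bound to an aromatic carbon. Among the compounds with values here, the only measured step bearing on this change is a step that the two limits leave unreadable from compound 1 to compound 2, so it offers no size to carry over. The expected change in this assay is an at least 1.3-fold lower number from compound 2 to compound 4 (0.14 log units; that floor lies within the scatter), with no firm direction and nothing expected beyond the scatter. For compound 4 the estimate is 180000 nM, with an expected range of 60000 nM to 250000 nM.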

Compound 4, half-maximal cytotoxic concentration: 18000 nM
The estimate for compound 4 lay 10-fold (1.00 log units) above the measured number; measured number below the stated range.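

In this assay, compound 4 gives the first actual number rather than a limit, showing that the group on this saturated chain carbon bound to an aromatic carbon can change how much compound the cells tolerate. Diisopropylamino gives an at least 13-fold lower number from compound 2 to compound 4 (1.14 log units; beyond the scatter), and it gives an at least 13-fold lower number from compound 1 to compound 4 (1.14 log units; beyond the scatter). Both sizes are only floors, since the starting values are limits, and steps between two limits cannot be read: the limit of > 250000 nM in this assay, at which 2 of the 4 values shown sit.

Going by these compounds, it remains open whether the lower number goes with the amine nitrogen itself or with its two isopropyl groups. Dimethylamino or morpholine at this place would help separate the two.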